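The compounds below may be only part of what the source reports. "The series", "measured", "known", "first", "only" and "open" are said of these compounds alone.

Compound 1, `Cc1c(C=O)cc(-c2ccc(S(C)(=O)=O)cc2)n1-c1ccccc1`: 32%
Compound 2, `Cc1c(/C=N\O)cc(-c2ccc(S(C)(=O)=O)cc2)n1-c1ccccc1`: 53%
Compound 3, `Cc1c(C#N)cc(-c2ccc(S(C)(=O)=O)cc2)n1-c1cccc(F)c1`: 33%

In a functional assay on the whole organism (strain Swiss albino) for inhibition, with Mus musculus as the target, in the writhing test, with a stated time of 30 min, at a dose of 20 mg/kg by the oral route (on this read-out lower numbers stand for a weaker effect and higher numbers for a stronger effect at the one dose given), compound 3 gives 33%, the second highest of the three numbers. Compound 1 gives 32%, which sits within the scatter of the value of compound 3, so the two cannot be told apart. Compound 2 gives 53%, which lies beyond the scatter above compound 3. For the measured compounds named here, the only step between measured compounds that differ in one place is a number 21 percentage points higher from compound 1 to compound 2 (beyond the scatter), a change of a group on an aromatic carbon of the shared core, at a different place and of a different kind from the change now considered.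

Compound 4, `Cc1c(C#N)cc(-c2ccc(S(C)(=O)=O)cc2)n1-c1ccccc1`, differs from compound 3 by hydrogen in place of fluoro on an aromatic carbon, that is, 3-fluorophenyl to phenyl. Going by the values given here, no measured step bears on hydrogen in place of fluoro on an aromatic carbon, so the data give no ground to expect a shift beyond the scatter; the expected step is no change at the digits printed from compound 3 to compound 4 (within the scatter). Compound 4 is therefore estimated at 33% in this assay, with a range from 20% to 46%.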

Compound 4, a percentage reported as inhibition, in the whole organism at one dose (the size of the read-out at that dose, not a potency): 42%
The estimate for compound 4 lay 9 percentage points below the measured number; the range from low to high includes it.
By their numbers in this assay, from the lowest: compounds 1, 3 and 4 (each within the scatter of the next); then compound 2.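

In this assay, hydrogen in place of fluoro gives a number 9 percentage points higher from compound 3 to compound 4 (within the scatter) and so does not separate 3-fluorophenyl from phenyl at this place on the aromatic ring. With phenyl held constant, nitrile in place of formyl gives a number 10 percentage points higher from compound 1 to compound 4 (within the scatter) and leaves those two groups unseparated as well. For the compounds shown here, the oxime is set apart from the nitrile by a number 11 percentage points lower from compound 2 to compound 4 (beyond the scatter) and now stands beyond the scatter of both of its phenyl-bearing counterparts, which the earlier compounds could show only against formyl.

The compounds shown leave open whether chloro or methoxy in place of fluoro on the phenyl ring would read differently from hydrogen. They also leave open how an amine or a carboxylic acid would read in place of the oxime or nitrile.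

Nothing at hand explains these numbers.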